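A few compounds are considered here, and "the series" means these few. Any claim that something is new, unique, unknown or untested is made for them only; others in the source may bear on it.

In a functional assay on MDA-MB-231 cells (Homo sapiens) for inhibition, read by MTT assay, with a stated time of 48 h (a lower number here means a stronger inhibitor of growth, a higher number a weaker inhibitor of growth), compound 1 (`S=C(NCc1ccccc1)Nc1ccc2ncnc(Nc3ccccc3Br)c2c1`) gives > 30000 nM, which is a limit of the assay and not a number. Going by the values given here, compound 2 (`CC(C)(C)c1ccc(Nc2ncnc3ccc(NC(=S)NCc4ccccc4)cc23)cc1`) gives 8700 nM, the only actual number so far. Compound 3 (`NS(=O)(=O)c1ccc(Nc2ncnc3ccc(NC(=S)NCc4ccccc4)cc23)cc1`) carries sulfamoyl in place of tert-butyl on an aromatic carbon, para to a large group: sulfamoyl in place of tert-butyl on an aromatic carbon. Among the compounds with values here, one measured step bears on this, 4-(tert-butyl)phenyl in place of 2-bromophenyl, which gives an at least 3.4-fold lower number from compound 1 to compound 2 (0.53 log units; beyond the scatter). Within the data shown here, that step shows that a change in this aryl group can move the number in this assay, but no measured compound carries sulfamoyl, so direction and size remain poorly defined. A modest move to a higher number is expected, not clearly beyond the scatter. The expected step is a 1.6-fold higher number from compound 2 to compound 3 (0.21 log units; within the scatter). For compound 3 the estimated value is 14000 nM, with an expected range of 4000 nM to 30000 nM.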

Compound 3, concentration for 50% growth inhibition: > 30000 nM
Compound 3 was reported as a limit (the forecaster's own chance of this, stated with the estimate: 30%); middle value at least 2.1-fold (0.33 log units) from the limit.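

Sulfamoyl in place of tert-butyl on an aromatic carbon, para to a large group, gives an at least 3.4-fold higher number from compound 2 to compound 3 (0.53 log units; beyond the scatter) in this assay. The earlier step changed the aryl group as a whole, whereas this one keeps the group at the same place and exchanges only the substituent, and that exchange alone moves the result beyond the scatter. The step from compound 1 to compound 3 cannot be read, as both values are limits and not numbers: the limit of > 30000 nM in this assay, at which 2 of the 3 values shown sit.

Going by these compounds alone, with compound 2 the only compound giving an actual number, it remains open how far compound 3 lies past its limit. Also open, from the compounds shown here alone, is what a methyl group, a methoxy group or a carboxylic acid on this same carbon would give, and so whether tert-butyl is favoured or sulfamoyl is disfavoured here.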